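A few compounds are considered here, and "the series" means these few. Any claim that something is new, unique, unknown or untested is made for them only; others in the source may bear on it.

Three measured compounds share one core and differ only in what sits on the outer benzamide ring. Compound 1 `COCCOC(=O)c1ccc(F)c(C(=O)Nc2cccc(-c3cc(C(=O)Nc4ccncc4F)ccc3CN)c2)c1`, compound 2 `CCCOC(=O)c1ccc(NC(=O)c2cccc(-c3cc(C(=O)Nc4ccncc4F)ccc3CN)c2)cc1` and compound 3 `COC(=O)c1ccc(C(=O)Nc2cccc(-c3cc(C(=O)Nc4ccncc4F)ccc3CN)c2)cc1` were each tested in an assay on cells for inhibition of Rho-associated protein kinase 2 (Homo sapiens), read by radiometric assay and 33P incorporation, in the presence of a further agent that is not named here; a higher number here means a weaker inhibitor, a lower number a stronger inhibitor. In this assay compound 1 gives < 1 nM, which is a limit of the assay and not a number. Compound 3 likewise gives < 1 nM, again a limit. Compound 2, the starting point of this step, gives < 1 nM in this assay, also a limit. Among the compounds with values here, its standing therefore cannot be placed above or below the other two: all three rest on (the limit of < 1 nM in this assay, at which 3 of the 3 values shown sit), and no step between measured compounds can be drawn.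

Compound 4 `NCc1ccc(C(=O)Nc2ccncc2F)cc1-c1cccc(C(=O)Nc2ccccc2)c1` has not yet been measured. Relative to compound 2 the change is hydrogen in place of propoxycarbonyl on an aromatic carbon, so that the outer ester is gone and a plain phenyl remains on the amide. Since the measured pairs all end at the limit, the size of the step from compound 2 to compound 4 in this assay cannot be read from them; a modest loss, up to the edge of the scatter, is expected as an at least 1.5-fold higher number from compound 2 to compound 4 (0.17 log units; that floor lies within the scatter). Compound 4 is accordingly estimated at 1.5 nM, within 0.3 nM to 8 nM, with a fair chance that only a limit is reported.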

Compound 4, half-maximal inhibitory concentration: < 1 nM
Compound 4: a limit, no number; the forecaster's own chance of this, stated with the estimate: 45%; middle value at least 1.5-fold (0.17 log units) from the limit.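

No step from compound 2 to compound 4 can be read, because both values rest on the same limit and neither is a number: the limit of < 1 nM in this assay, at which 4 of the 4 values shown sit.

The compounds shown leave open whether losing propoxycarbonyl changes the inhibition at all, and how the four compounds rank against one another.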